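This account rests on a few compounds, and the source may have more. Where it says the series, first, only, none or still open, it means among the compounds named here.

Measured in an assay on isolated protein for inhibition of Amine oxidase [flavin-containing] B (Homo sapiens), read by fluorescence; a higher number here means a weaker inhibitor, a lower number a stronger inhibitor:
compound 1 `O=C(/C=C/c1cccc(O)c1)c1cc(O)c(O)c([N+](=O)[O-])c1` gives 55800 nM.
compound 2 `CC(=O)N1N=C(c2cc(O)c(O)c([N+](=O)[O-])c2)CC1c1nccs1` gives 68200 nM.
compound 3 `CC(=O)N1N=C(c2cc(O)c(O)c([N+](=O)[O-])c2)CC1c1cccs1` gives 69200 nM.

All three share the same core and differ only in the groups around it, and all three numbers lie within the usual scatter of one another. Compound 3 holds the highest of the three numbers, but its gap to compound 2, a 1.0-fold higher number from compound 2 to compound 3 (0.01 log units; within the scatter), and its gap to compound 1 are both within the scatter, so in this assay the three compounds cannot be told apart.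

Compound 4 `CC(=O)N1N=C(c2cc(O)c(O)c([N+](=O)[O-])c2)CC1c1ccc(C#N)cc1` differs from compound 3 in one place: 4-cyanophenyl in place of thiophen-2-yl on a saturated ring carbon. Among the compounds with values here, only one measured step touches that same saturated ring carbon, a 1.0-fold higher number from compound 2 to compound 3 (0.01 log units; within the scatter), and it exchanged one five-membered aromatic ring for another without moving the number. Within the data shown here, no measured step replaces a five-membered ring by a six-membered one or brings in a nitrile, so the present change is not directly covered. Compound 4 is therefore expected to show a step of a 1.1-fold lower number from compound 3 to compound 4 (0.03 log units; within the scatter) that stays within the scatter, since a 1.0-fold higher number from compound 2 to compound 3 (0.01 log units; within the scatter) was itself flat. Compound 4 is estimated at 65000 nM in this assay, with a range from 25000 nM to 160000 nM.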

Compound 4, half-maximal inhibitory concentration: 83200 nM
Compound 4: the middle estimate sits 1.3-fold (0.11 log units) below what was measured; low and high end bracket the measured number.
By their numbers in this assay, from the lowest: compounds 1, 2, 3 and 4 (each within the scatter of the next).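

Until now, this saturated ring carbon had only seen one five-membered aromatic ring swapped for another, so it was unknown whether the flat result would hold for a different kind of group. Within the data shown here, with 4-cyanophenyl, which brings a six-membered aromatic ring of carbon only, more heavy atoms and a nitrile, the number still does not separate from those of the earlier compounds in this assay: the steps are (a 1.2-fold higher number from compound 3 to compound 4 (0.08 log units; within the scatter)) and (a 1.2-fold higher number from compound 2 to compound 4 (0.09 log units; within the scatter)), so thiophen-2-yl, 1,3-thiazol-2-yl and 4-cyanophenyl cannot be told apart at this position. No supporting information is available to explain this flat result.

Still open, on these data alone, is whether any group at this position can move the number beyond the scatter, for instance an amine or a carboxylic acid on the aromatic ring in place of the nitrile, or a longer chain on the saturated ring carbon. Also open is whether a longer chain in place of the acetyl group would change the reading, since every step shown so far concerns only the saturated ring carbon.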